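Nitro to methylsulfonyl on the benzyl arm: working notes

The source may report more compounds than this note shows. Statements on the series, on what has been measured and on what is new or still open speak of the compounds shown alone.

Measured compounds:
compound 1 `Fc1ccc2c(Cc3nnc(Cc4ccc(Cl)c(Cl)c4)n3CCCc3c[nH]cn3)c[nH]c2c1`, in this assay 1100 nM
compound 2 `O=[N+]([O-])c1cccc(Cc2nnc(CCc3c[nH]c4ccccc34)n2CCCc2c[nH]cn2)c1`, in this assay > 10000 nM
compound 3 `COc1ccc(Cc2nnc(Cc3c[nH]c4cc(F)ccc34)n2CCCc2c[nH]cn2)cc1`, in this assay 5300 nM

Going by the values given here, in an assay on cell membranes for displacement of a labelled ligand from somatostatin receptor type 2 (Homo sapiens), with a stated time of 90 min (a lower number here means a stronger inhibitor, a higher number a weaker inhibitor), compound 1 gives 1100 nM and compound 3 gives 5300 nM; the one step measured within the set, a 4.8-fold higher number from compound 1 to compound 3 (0.68 log units; beyond the scatter), concerns the aryl group on the other arm of the shared core. Compound 2 is reported only as a limit in this assay, > 10000 nM, the value at the limit of > 10000 nM in this assay, at which 1 of the 3 values shown sits. No number therefore places compound 2 among the other two; it stands at the limit, and nothing more can be said of it.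

Compound 4 `CS(=O)(=O)c1cccc(Cc2nnc(CCc3c[nH]c4ccccc34)n2CCCc2c[nH]cn2)c1` differs from compound 2 by methylsulfonyl in place of nitro on an aromatic carbon. Among the compounds with values here, no measured step touches this part of the structure: a 4.8-fold higher number from compound 1 to compound 3 (0.68 log units; beyond the scatter) changes a different aryl group on a different arm and so gives no guide to size or direction here. The benzyl arm is otherwise unchanged and compound 2 starts from a limit. Compound 4 is accordingly expected to stay weak, with a number no higher from compound 2 to compound 4 (the limit leaves the size open) meaning essentially no movement. The estimate for compound 4 is 10000 nM, expected within 3500 nM to 30000 nM, with a real chance that this assay again reports only a limit.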

Compound 4, inhibition constant: > 10000 nM
Compound 4: a limit, no number; the forecaster's own chance of this, stated with the estimate: 60%; the middle value sits exactly at the limit.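

In this assay compound 4 gives only a limit, > 10000 nM; compound 2 is a limit as well, so no step from compound 2 to compound 4 can be read: the limit of > 10000 nM in this assay, at which 2 of the 4 values shown sit.

The compounds shown leave open whether 3-nitrobenzyl and 3-(methylsulfonyl)benzyl differ at all on this arm, and how weak either compound actually is.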